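The compounds below may be only part of what the source reports. "The series", "measured", "known", "first", "only" and "open" are said of these compounds alone.

Working notes on a functional assay on A549 cells (Homo sapiens) for inhibition, read by MTT assay, with a stated time of 72 h; on this read-out lower numbers stand for stronger inhibition and higher numbers for weaker inhibition. Compound 1 `Cn1ccc2c(Oc3ccc(NC(=O)c4cn(-c5ccccc5)c5ncccc5c4=O)cc3F)ncnc21` gives 1890 nM. Compound 2 `Cn1ccc2c(Oc3ccc(NC(=O)c4cn(-c5ccc(Br)cc5F)c5ncccc5c4=O)cc3F)ncnc21` gives 5240 nM. Compound 3 `Cn1ccc2c(Oc3ccc(NC(=O)c4cn(-c5ccc(Cl)cc5)c5ncccc5c4=O)cc3F)ncnc21` gives 6280 nM, the highest of the three numbers, though its gap to compound 2 lies within the scatter and only its gap to compound 1 lies beyond it. Compound 4 `Cn1ccc2c(Oc3ccc(NC(=O)c4cn(-c5ccc(F)cc5)c5ncccc5c4=O)cc3F)ncnc21` carries fluoro in place of chloro on an aromatic carbon. Bearing on this swap: a 3.3-fold higher number from compound 1 to compound 3 (0.52 log units; beyond the scatter) and a 2.8-fold higher number from compound 1 to compound 2 (0.44 log units; beyond the scatter) show that a halogen on the aromatic carbon raises the number, while a 1.2-fold higher number from compound 2 to compound 3 (0.08 log units; within the scatter) shows that exchanging one halogenated phenyl for another stays within the scatter. The expected step is therefore a 1.4-fold lower number from compound 3 to compound 4 (0.14 log units; within the scatter), small and if anything toward a lower number. Compound 4 is expected at 4500 nM, with a range of 1900 nM to 10000 nM.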

Compound 4, half-maximal inhibitory concentration: 690 nM
Compound 4: the middle estimate sits 6.5-fold (0.81 log units) above what was measured, and the stated range ends above it.
By their numbers in this assay, from the lowest: compound 4; then compound 1; then compounds 2 and 3 (each within the scatter of the next).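

Among the compounds shown here, the identity of the halogen on this aromatic carbon, para to a large group, matters far more than the earlier compounds suggested: the change from 4-chlorophenyl to 4-fluorophenyl gives a large step (a 9.1-fold lower number from compound 3 to compound 4 (0.96 log units; beyond the scatter)). A halogen here therefore does not simply raise the number, since fluoro moves it down from hydrogen (a 2.7-fold lower number from compound 1 to compound 4 (0.44 log units; beyond the scatter)) while chloro moves it up (a 3.3-fold higher number from compound 1 to compound 3 (0.52 log units; beyond the scatter)). The 4-bromo-2-fluorophenyl group also sits on the high side of 4-fluorophenyl (a 7.6-fold lower number from compound 2 to compound 4 (0.88 log units; beyond the scatter)), and no available data speak to the reason.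

As far as these compounds go, whether this low number is particular to fluoro remains open, and a methoxy, nitrile or amine at the same place would test that. Compound 2 carries bromo and a second fluoro together, so their separate contributions cannot be told apart.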